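The compounds below may be only part of what the source reports. "The series", "measured", "known", "first", "only" and "open" are said of these compounds alone.

Compound 1 `O=C(/C=C/C(=O)N1C/C(=C\c2ccccc2)C(=O)/C(=C/c2ccccc2)C1)Nc1ccc(Cl)c(Cl)c1` was tested in a functional assay on L1210 cells (Mus musculus) for cytotoxicity (a lower number here means a stronger inhibitor, a higher number a weaker inhibitor), and compound 1 gives 7500 nM. Among the three measured compounds this is the highest number, so compound 1 is the weakest of the three. Compound 2 `O=C(/C=C/C(=O)N1C/C(=C\c2ccc([N+](=O)[O-])cc2)C(=O)/C(=C/c2ccc([N+](=O)[O-])cc2)C1)Nc1ccc(Cl)c(Cl)c1`, whose outer rings on the shared core carry nitro groups, gives 1700 nM in this assay, and compound 3 `O=C(/C=C/C(=O)N1C/C(=C\c2ccc([N+](=O)[O-])cc2)C(=O)/C(=C/c2ccc([N+](=O)[O-])cc2)C1)Nc1ccc([N+](=O)[O-])cc1` gives 1000 nM. Among the measured compounds shown here, only one measured step changes a single place: replacing the 3,4-dichlorophenyl on the amide-type nitrogen by a 4-nitrophenyl gave a 1.7-fold lower number from compound 2 to compound 3 (0.23 log units; within the scatter), so that swap of the aryl group on the amide nitrogen left the number essentially unchanged.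

Compound 4 `CC(=O)c1ccc(NC(=O)/C=C/C(=O)N2C/C(=C\c3ccccc3)C(=O)/C(=C/c3ccccc3)C2)cc1` differs from compound 1 at exactly this place: 4-acetylphenyl in place of 3,4-dichlorophenyl on an amide-type nitrogen. For the measured compounds named here, the one measured step that bears on it is the swap from compound 2 to compound 3, which changed the same position and stayed within the scatter, so no step beyond the scatter is expected here either in this assay. Compound 4 is therefore expected to give about 6000 nM, within a range from 2500 nM to 15000 nM. That estimate means a 1.3-fold lower number from compound 1 to compound 4 (0.10 log units; within the scatter) is expected, a step that stays within the scatter.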

Compound 4, half-maximal inhibitory concentration: 5500 nM
Beside the measured number, compound 4's estimate is 1.1-fold (0.04 log units) above it, and the stated range covers the measured number.
By their numbers in this assay, from the lowest: compounds 3 and 2 (each within the scatter of the next); then compounds 4 and 1 (each within the scatter of the next).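

In this assay, putting 4-acetylphenyl in place of 3,4-dichlorophenyl on the amide-type nitrogen gives a 1.4-fold lower number from compound 1 to compound 4 (0.13 log units; within the scatter), even though the two chlorine atoms leave and a group with a hydrogen-bond acceptor enters. Until now, this position had been read only on compounds whose outer rings carry nitro groups, through a 1.7-fold lower number from compound 2 to compound 3 (0.23 log units; within the scatter); compounds 1 and 4 have plain outer rings, so the aryl group at this place has now been exchanged on two versions of the shared core, and neither exchange goes beyond the scatter. No measurement shown here explains why these two exchanges make so little difference.

Going by these compounds, all the groups compared at this position are substituted phenyl rings, so it remains open whether a carboxylic acid or an amine on that ring, or a longer chain in place of the ring, would also stay within the scatter. On these data alone, it is also open whether 4-acetylphenyl would behave the same way on the nitro-bearing version of the core, as compound 4 carries it only on the plain one.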